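Swapping the fluorine pattern on the benzyl arm

The source may hold more compounds than are shown below. What is called first, only, known or untested is meant among the compounds shown, and "the series" means these compounds.

Compound 1 `CC1(C)c2[nH]nc(NC(=O)c3ccc(F)cc3)c2CN1Cc1cc(F)cc(F)c1`: 350 nM in an assay on Sf21 cells for inhibition of high affinity nerve growth factor receptor (Homo sapiens), read by HTRF, with a stated time of 30 min, in the presence of a further agent that is not named here; a higher number here means a weaker inhibitor, a lower number a stronger inhibitor
Compound 2 `CN1CCN(c2ccc(C(=O)Nc3n[nH]c4c3CN(Cc3cccc(F)c3F)C4(C)C)cc2)CC1`: 17 nM in this assay

Compound 2 has the lowest number of the two measured, and its gap to compound 1 lies beyond the scatter; the two differ in more than one place, so no single change can be read from that gap. Compound 3 `CN1CCN(c2ccc(C(=O)Nc3n[nH]c4c3CN(Cc3cc(F)cc(F)c3)C4(C)C)cc2)CC1` carries the same atoms as compound 2, joined differently: 3,5-difluorophenyl in place of 2,3-difluorophenyl on a saturated chain carbon bound to an amine nitrogen in a ring. Within the data shown here, no measured pair isolates this change, so I expect at most a small step, a 1.8-fold higher number from compound 2 to compound 3 (0.25 log units; within the scatter), within or near the scatter. For compound 3 in this assay I estimate 30 nM, between 8 nM and 120 nM.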

Compound 3, half-maximal inhibitory concentration: 17 nM
Beside the measured number, compound 3's estimate is 1.8-fold (0.25 log units) above it, and the stated range covers the measured number.
By their numbers in this assay, from the lowest: compounds 2 and 3 (each within the scatter of the next); then compound 1.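

In this assay the swap from 2,3-difluorobenzyl to 3,5-difluorobenzyl gives no change at the digits printed from compound 2 to compound 3 (within the scatter) and so these two fluorine patterns cannot be told apart on this arm. With the 3,5-difluorobenzyl arm held constant, the earlier gap can now be read as a single change: 4-methylpiperazin-1-yl in place of fluoro on an aromatic carbon gives a 21-fold lower number from compound 1 to compound 3 (1.31 log units; beyond the scatter) and this large step is the only one here beyond the scatter. Nothing available explains either result.

Still open, as far as these compounds go, is how a plain benzyl or a 2,6-difluorobenzyl arm would compare. From the compounds shown here alone, a morpholine in place of the 4-methylpiperazin-1-yl group is equally open.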